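Series notes: pyridinyl amide replacing pyrazolyl at the aromatic carbon

A few compounds are considered here, and "the series" means these few. Any claim that something is new, unique, unknown or untested is made for them only; others in the source may bear on it.

Compound 3 `Cn1cc(-c2cnc(NCc3c(F)ccc4c3CCO4)c3cn[nH]c(=O)c23)cn1` gives 2.7 in a physicochemical assay for lipophilicity, using the shake flask method, in phosphate buffer, measured as octanol-water partition, with a stated time of 30 min, at pH 7.4 (a higher number here means a more lipophilic compound, a lower number a more polar compound), and stands second highest of the three measured values. Compound 2 `Cc1cc(-c2cnc(NCc3c(F)ccc4c3CCO4)c3cn[nH]c(=O)c23)n(C)n1` gives 3; the step of a number 0.30 log units lower from compound 2 to compound 3 (within the scatter) is within the scatter. Compound 1 `Cc1nccn1-c1cnc(NCc2c(F)ccc3c2CCO3)c2cn[nH]c(=O)c12` gives 2.1; the step of a number 0.60 log units higher from compound 1 to compound 3 (beyond the scatter) is beyond it, as is a number 0.90 log units higher from compound 1 to compound 2 (beyond the scatter).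

Compound 4 `CNC(=O)c1ccc(-c2cnc(NCc3c(F)ccc4c3CCO4)c3cn[nH]c(=O)c23)c(C)n1` differs from compound 3 in one place: 2-methyl-6-(methylcarbamoyl)pyridin-3-yl in place of 1-methyl-1H-pyrazol-4-yl on an aromatic carbon. Within the data shown here, none of the measured steps exchanges a five-membered group for a six-membered one, and none introduces a hydrogen-bond donor, so the measured steps set only the scale of recent changes, all modest. For compound 4 a step of about a number 0.10 log units lower from compound 3 to compound 4 (within the scatter) is expected, within the scatter. Compound 4 is estimated at 2.6, range 2 to 3.2.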

Compound 4, distribution coefficient: 2.9
Beside the measured number, compound 4's estimate is 0.30 log units below it, and the stated range covers the measured number.
By their numbers in this assay, from the lowest: compound 1; then compounds 3, 4 and 2 (each within the scatter of the next).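

At this position on an aromatic carbon, a six-membered aromatic ring carrying a hydrogen-bond donor now stands in for the five-membered groups, and in this assay both steps to the pyrazoles lie within the scatter: a number 0.20 log units higher from compound 3 to compound 4 (within the scatter) and a number 0.10 log units lower from compound 2 to compound 4 (within the scatter). Only the 2-methyl-1H-imidazol-1-yl group stays apart, with a number 0.80 log units higher from compound 1 to compound 4 (beyond the scatter), leaving compound 1 lowest of the four. Nothing measured here accounts for this result.

Going by these compounds, the separate shares of the methylcarbamoyl and 2-methyl groups in compound 4 remain open. So does the reading in this assay for a carboxylic acid or a primary amine in place of the methylcarbamoyl group.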